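Chloro for fluoro on the 4-fluorophenyl arm of compound 2

The compounds below may be only part of what the source reports. "The series", "measured", "known", "first", "only" and "open" are said of these compounds alone.

Of the compounds shown here, three on a shared core have been measured in a functional assay on U-87MG ATCC cells (Homo sapiens) for antiproliferative activity, read by MTT assay, with a stated time of 48 h; a lower number here means a stronger inhibitor, a higher number a weaker inhibitor. Compound 1 `O=C(/C=C\Nc1ccc(Cl)cc1)c1cn(-c2ccccc2)nc1-c1ccc(F)cc1` gives 8900 nM in this assay. Compound 3 `COc1ccc(N/C=C\C(=O)c2cn(-c3ccccc3)nc2-c2ccc(F)cc2)cc1` gives 2500 nM in this assay. For compound 2 `O=C(/C=C\Nc1ccc(C(F)(F)F)cc1)c1cn(-c2ccccc2)nc1-c1ccc(F)cc1` only a limit of the assay is known, > 50000 nM in this assay. On the numbers shown compound 2 therefore stands at the weak end of the three, sitting at the limit of > 50000 nM in this assay, at which 1 of the 3 values shown sits, rather than at a number.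

The measured steps are an at least 5.6-fold higher number from compound 1 to compound 2 (0.74 log units; beyond the scatter), a 3.6-fold lower number from compound 1 to compound 3 (0.55 log units; beyond the scatter) and an at least 20-fold lower number from compound 2 to compound 3 (1.30 log units; beyond the scatter). All three change the group on the aromatic carbon that carries chloro, trifluoromethyl or methoxy.

Compound 4 `O=C(/C=C\Nc1ccc(C(F)(F)F)cc1)c1cn(-c2ccccc2)nc1-c1ccc(Cl)cc1` differs from compound 2 by chloro in place of fluoro on an aromatic carbon, keeping the trifluoromethyl of compound 2 in place. Within the data shown here, none of the measured steps touches the 4-fluorophenyl; they bear on the other substituent and give no direction for this change. Among the measured compounds shown here, with no step of this kind to draw on, no shift beyond the scatter is expected in this assay, and compound 4 is expected to remain at or near the limit of compound 2.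

For compound 4 the estimate in this assay is 50000 nM, between 15000 nM and 160000 nM. The expected step is a number no higher from compound 2 to compound 4 (the limit leaves the size open).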

Compound 4, half-maximal inhibitory concentration: > 50000 nM
Compound 4: only a limit was reported; the forecaster's own chance of this, stated with the estimate: 60%; the middle value lies on the limit itself.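

Compound 2 and compound 4 both rest on a limit and not on a number, so the step between them cannot be read in this assay: the limit of > 50000 nM in this assay, at which 2 of the 4 values shown sit. Still open, from the compounds shown here alone, is what 4-chlorophenyl in place of 4-fluorophenyl does to the number alongside the chloro of compound 1 or the methoxy of compound 3.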